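Chain length and a hydroxycarbamate: estimating compound 4

A few compounds are considered here, and "the series" means these few. Any claim that something is new, unique, unknown or untested is made for them only; others in the source may bear on it.

Measured so far in a functional assay on ES2 cells (Homo sapiens) for inhibition, read by MTT assay, with a stated time of 48 h; a higher number here means a weaker inhibitor, a lower number a stronger inhibitor:
compound 1, `O=C(CCCOc1no[n+]([O-])c1S(=O)(=O)c1ccccc1)NO`, gives 3780 nM;
compound 2, `O=C(CCCCOc1no[n+]([O-])c1S(=O)(=O)c1ccccc1)NO`, gives 2530 nM;
compound 3, `O=C(CCCCCCCOc1no[n+]([O-])c1S(=O)(=O)c1ccccc1)NO`, gives 1320 nM.

Compound 3 has the lowest number of the three; its nearest neighbour is compound 2 and its furthest is compound 1. The steps of a 1.5-fold lower number from compound 1 to compound 2 (0.17 log units; within the scatter) and a 1.9-fold lower number from compound 2 to compound 3 (0.28 log units; within the scatter) each stay within the scatter, while a 2.9-fold lower number from compound 1 to compound 3 (0.46 log units; beyond the scatter) is modest but beyond it. Compound 4, `O=C(NO)OCCOCCOc1no[n+]([O-])c1S(=O)(=O)c1ccccc1`, differs from compound 3 by 2-((hydroxycarbamoyl)oxy)ethoxy in place of 5-(hydroxycarbamoyl)pentyl on a saturated chain carbon, two bonds along the chain from an oxygen on an aromatic ring. For the measured compounds named here, no measured step exchanges hydroxycarbamoyl for a hydroxycarbamate or brings in the ether oxygens, so only the chain-length steps bear on it, and they were small. For compound 4 in this assay a somewhat higher number is therefore expected, with a 1.7-fold higher number from compound 3 to compound 4 (0.22 log units; within the scatter), giving an estimated 2200 nM and a range from 900 nM to 5500 nM.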

Compound 4, half-maximal inhibitory concentration: 18100 nM
Beside the measured number, compound 4's estimate is 8.2-fold (0.92 log units) below it, and the stated range ends below it.
By their numbers in this assay, from the lowest: compounds 3, 2 and 1 (each within the scatter of the next, the first and the last beyond it); then compound 4.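

Chain length at this position had moved the number only a little, but 2-((hydroxycarbamoyl)oxy)ethoxy moves it much further in this assay: a 14-fold higher number from compound 3 to compound 4 (1.14 log units; beyond the scatter), a 7.2-fold higher number from compound 2 to compound 4 (0.85 log units; beyond the scatter) and a 4.8-fold higher number from compound 1 to compound 4 (0.68 log units; beyond the scatter). Compound 4 therefore lies beyond the scatter of all three hydroxycarbamoyl chains. Nothing measured here explains this jump.

This change brings in the hydroxycarbamate and the ether oxygens together, and the compounds shown do not separate the two. A hydroxycarbamate on an all-carbon chain, or a hydroxycarbamoyl chain with an ether oxygen, would tell them apart.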